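The compounds below may be only part of what the source reports. "The series", "measured", "known", "first", "only" and "open" are said of these compounds alone.

Compounds measured so far:

Compound 1, `Cc1ccsc1-c1cc(-c2ccco2)cc(-c2ccc(Cl)cc2)n1`, gives 26700 nM in a functional assay on DU-145 cells (Homo sapiens) for cytotoxicity, read by ELISA, with a stated time of 4 days; a lower number here means a stronger inhibitor, a higher number a weaker inhibitor.
Compound 2, `Cc1ccc(-c2cc(-c3ccoc3)cc(-c3ccc(Cl)s3)n2)o1`, gives 33400 nM in this assay.

Both numbers sit high, and neither compound is a strong inhibitor in this assay. For the measured compounds named here, of the two numbers, the one for compound 2 is the higher; compound 1 comes closest, and the gap between the two lies within the usual scatter of repeated measurements, so the two compounds are not separated by these data.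

Compound 3, `Cc1ccc(-c2cc(-c3ccoc3)cc(-c3ccc(Cl)s3)n2)cc1`, is the next compound to be measured in this assay. It differs from compound 2 in one place: 4-methylphenyl in place of 5-methylfuran-2-yl on an aromatic carbon. Going by the values given here, no pair of measured compounds shows this change, so there is no step to lean on. Among the compounds with values here, with only two values on hand, both close together, the expected step from compound 2 to compound 3 is estimated at a 1.1-fold lower number from compound 2 to compound 3 (0.05 log units; within the scatter), that is, none beyond the scatter. Compound 3 is therefore expected to give about 30000 nM in this assay, with a range from 10000 nM to 90000 nM.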

Compound 3, half-maximal inhibitory concentration: 25300 nM
Compound 3: the middle estimate sits 1.2-fold (0.07 log units) above what was measured; the range from low to high includes it.
By their numbers in this assay, from the lowest: compounds 3, 1 and 2 (each within the scatter of the next).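

At the aromatic carbon next to the ring nitrogen, 4-methylphenyl in place of 5-methylfuran-2-yl gives a 1.3-fold lower number from compound 2 to compound 3 (0.12 log units; within the scatter) in this assay, the first step read at any position in this series. The exchange replaces a five-membered aromatic ring with one hetero atom by a six-membered aromatic ring of carbon only and takes away the hydrogen-bond acceptor counted on the leaving group, yet compound 2 and compound 3 are not separated by these data, and neither is a strong inhibitor.

Going by these compounds, whether any group at this position can move the number beyond the scatter remains open, since only these two aromatic rings have been compared here; an amine, a carboxylic acid or a longer alkyl chain in their place would test this. Also open, on these data alone, is whether the furan-3-yl group or the 5-chlorothiophen-2-yl group matters more, since neither has yet been changed on its own in a step between measured compounds.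

No measurement bearing on why this exchange gives such a small step is available.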